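A few compounds are considered here, and "the series" means these few. Any claim that something is new, unique, unknown or untested is made for them only; others in the source may bear on it.

Four compounds share a core in which a five-membered ring carrying a methyl group bears a phenol on one carbon and either an acyl or a sulfonyl group on one nitrogen. Compound 1 `CC1=NN(C(=O)c2ccc([N+](=O)[O-])cc2)C(c2ccccc2O)C1` carries a nitro group on its benzoyl part, and compound 2 `CC1=NN(C(=O)c2ccc(C)cc2)C(c2ccccc2O)C1` differs from it only by methyl in place of nitro on an aromatic carbon. Compound 3 `CC1=NN(S(=O)(=O)c2ccc([N+](=O)[O-])cc2)C(c2cc(Br)cc(Br)c2O)C1` has a sulfonyl link instead of the carbonyl and two bromine atoms on the phenol; how its core differs from the core of compound 1 is not broken down here. Compound 4 `CC1=NN(S(=O)(=O)c2ccc(C)cc2)C(c2cc(Br)cc(Br)c2O)C1` is the still unmeasured partner of compound 3, and the change from compound 3 to compound 4 is methyl in place of nitro on an aromatic carbon, the same change as that from compound 1 to compound 2, made at a place described in the same words.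

In a functional assay on MGC-803 cells (Homo sapiens) for cytotoxicity, read by MTT assay, with a stated time of 48 h (a lower number here means a stronger inhibitor, a higher number a weaker inhibitor), compound 1 gives 50000 nM, while compound 2 gives 26300 nM, so that the step was a 1.9-fold lower number from compound 1 to compound 2 (0.28 log units; within the scatter). Compound 3 gives 40100 nM in this assay, a number that sits close to the values of both compound 1 and compound 2.

Going by the values given here, only that one earlier instance of the change is at hand, and it stayed inside the scatter. Compound 4 is therefore expected to give about 22000 nM in this assay, with a plausible range from 8000 nM to 60000 nM. The expected step is a 1.8-fold lower number from compound 3 to compound 4 (0.26 log units; within the scatter), an expectation that rests on a 1.9-fold lower number from compound 1 to compound 2 (0.28 log units; within the scatter) alone.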

Compound 4, half-maximal inhibitory concentration: "not active" (no number reported)
Compound 4 has no reported number here, and the estimate cannot be compared.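

In this assay, going by these compounds alone, compound 4 is reported only as not active, without a number, so no step from compound 3 to compound 4 can be read. The compounds shown leave open whether compound 3 and compound 4 lie within the usual scatter of each other, as compound 1 and compound 2 do. Nothing measured here offers an explanation for this result.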